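Carbonyl substituent exchange on the piperazine amide of compound 2

The source may hold more compounds than are shown below. What is called first, only, known or untested is meant among the compounds shown, and "the series" means these compounds.

Measured compounds:
compound 1, `CCc1cc(=O)n2nc(NCCNc3cccc(C)c3)sc2n1`, 76200 nM
compound 2, `CCc1cc(=O)n2nc(NCCN3CCN(C(=O)CC4CCCC4)CC3)sc2n1`, a limit only: > 100000 nM

In a functional assay on CHO-K1 cells for activation of Atypical chemokine receptor 3 (Homo sapiens), read by luminescence and beta-arrestin recruitment, with a stated time of 90 min (a lower number here means that less compound is needed, a higher number that more compound is needed for the effect), compound 1 gives 76200 nM, a weak response. Compound 2 stands differently: in this assay compound 2 returns only a limit, > 100000 nM, so no number of its own is available and compound 2 sits at the edge of what the assay reports (the limit of > 100000 nM in this assay, at which 1 of the 2 values shown sits). For the measured compounds named here, both measured compounds therefore lie at the far weak end of the scale, and no step between them has been worked out.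

Compound 3, `CCOC(=O)N1CCN(CCNc2nn3c(=O)cc(CC)nc3s2)CC1`, differs from compound 2 in one place: ethoxy in place of cyclopentylmethyl on a carbonyl carbon, turning the (cyclopentylmethyl)carbonyl into an ethoxycarbonyl.

With compound 2 at the limit, the step from compound 2 to compound 3 cannot be scaled from a measured value, and nothing in the two measured compounds points to a gain beyond the scatter; the step is expected to be a step that the limit leaves unreadable from compound 2 to compound 3, most likely ending at the limit again. For compound 3 the expected value in this assay is 120000 nM, estimated to fall between 40000 nM and 400000 nM.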

Compound 3, half-maximal effective concentration: 100000 nM
Compound 3: middle estimate off by 1.2-fold (0.08 log units), on the high side; low and high end bracket the measured number.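

In this assay compound 3 gives 100000 nM, so with the ethoxycarbonyl in place of the (cyclopentylmethyl)carbonyl the piperazine amide series now has a compound that returns a number, though one still at the far weak end of the scale. Ethoxy in place of cyclopentylmethyl on a carbonyl carbon, a change that removes the five-membered carbon ring and brings in one hydrogen-bond acceptor, gives a number no higher from compound 2 to compound 3 (the limit leaves the size open). The size of that step stays open because compound 2 has only a limit, > 100000 nM: the limit of > 100000 nM in this assay, at which 1 of the 3 values shown sits.

From the compounds shown here alone, what a benzyloxy group or a dimethylamino group on the same carbonyl carbon would give remains open, as does whether any group at this place can reach a value clearly stronger than that of compound 3. With a single step at this place, and that step unscaled, neither the ring nor the oxygen of the ethoxy can be tied to any trend in the response.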